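The source may report more compounds than this note shows. Statements on the series, on what has been measured and on what is new or still open speak of the compounds shown alone.

Compound 1 `CC(C)Cc1ccc2c(NCCCNCc3ccco3)ccnc2c1` gives 16000 nM in an ADME assay on HepG2 cells (Homo sapiens) for cytotoxicity, read by luminescence, CellTiter-Glo and ATP content, with a stated time of 72 h (a lower number here means that less compound is needed, a higher number that more compound is needed for the effect), and that is the highest of the three numbers measured here. Compound 2 `COc1cccc(CNCCCNc2ccnc3cc(CC(C)C)ccc23)c1O` gives 2920 nM and compound 3 `COc1ccc(F)cc1CNCCCNc1ccnc2cc(CC(C)C)ccc12` gives 2900 nM, so both sit well below compound 1: the steps of a 5.5-fold lower number from compound 1 to compound 2 (0.74 log units; beyond the scatter) and a 5.5-fold lower number from compound 1 to compound 3 (0.74 log units; beyond the scatter) are each beyond the scatter, while a 1.0-fold lower number from compound 2 to compound 3 (0.00 log units; within the scatter) lies within it.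

Compound 4 `N#Cc1ccc(Cc2ccc3c(NCCCNCc4ccco4)ccnc3c2)cc1` differs from compound 1 elsewhere: 4-cyanophenyl in place of isopropyl on a saturated chain carbon bound to an aromatic carbon. For the measured compounds named here, both measured steps touch the saturated chain carbon bound to an amine nitrogen at the other end of the molecule, and none changes the chain that carries the isopropyl group, so no measured step speaks directly to this change. With nothing to go on but the size of what enters, the step is expected to be small, with a modest drift to a lower number being possible but not secured; the estimated step is a 1.8-fold lower number from compound 1 to compound 4 (0.25 log units; within the scatter). Compound 4 is therefore expected to give about 9000 nM in this assay, within a range from 3000 nM to 30000 nM.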

Compound 4, half-maximal effective concentration: 7910 nM
For compound 4 the middle estimate is 1.1-fold (0.06 log units) above the measured one; the measured number falls inside the stated range.
By their numbers in this assay, from the lowest: compounds 3 and 2 (each within the scatter of the next); then compound 4; then compound 1.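

For the compounds shown here, the earlier steps all changed the saturated chain carbon bound to an amine nitrogen, so this is the first measured change on the saturated chain carbon bound to an aromatic carbon. In this assay, 4-cyanophenyl in place of isopropyl gives a 2.0-fold lower number from compound 1 to compound 4 (0.31 log units; beyond the scatter), so the number does not rise when a six-membered aromatic ring and a nitrile enter, although this step lies only just beyond the scatter. Nothing available here explains the shift.

Going by these compounds, it remains open whether the ring alone or its nitrile accounts for the step, a question that a plain benzyl or a 4-aminobenzyl group in place of isobutyl would address. Also open, on these data alone, is whether this change would add to those on the saturated chain carbon bound to an amine nitrogen.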